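Capping a ring amine in an integrin alpha-5/beta-1 antagonist series

The compounds below may be only part of what the source reports. "The series", "measured", "known", "first", "only" and "open" are said of these compounds alone.

Measured so far:
- compound 1 `Cc1cc(C)c(S(=O)(=O)N[C@@H](CNC(=O)C2=NO[C@]3(CN[C@H](CNc4ncc[nH]4)C3)C2)C(=O)O)c(C)c1`: 230 nM
- compound 2 `Cc1cc(C)c(S(=O)(=O)[C@@H](CNC(=O)C2=NOC3(CCC(CNc4nc5ccccc5[nH]4)CC3)C2)C(=O)O)c(C)c1`: 170 nM

Of the compounds shown here, two have been tested in a functional assay for antagonist activity at integrin alpha-5/beta-1 (Homo sapiens), read by ELISA; on this read-out lower numbers stand for stronger inhibition and higher numbers for weaker inhibition. Compound 1 gives 230 nM, which is the higher of the two numbers, while compound 2 gives 170 nM; the gap between these two values lies within the usual scatter, so nothing can be said about their order.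

Compound 3 `Cc1cc(C)c(S(=O)(=O)N[C@@H](CNC(=O)C2=NO[C@]3(C2)C[C@@H](CNc2ncc[nH]2)N(C(=O)OCc2cccnc2)C3)C(=O)O)c(C)c1` has not yet been measured. It differs from compound 1 by a single change, (((pyridin-3-yl)methoxy)carbonyl in place of hydrogen on an amine nitrogen in a ring). For the measured compounds named here, no step between measured compounds involves this kind of change, so there is no direct guide to what it does in this assay; the two values shown only set the level at which the shared core performs.

With nothing to indicate otherwise, the step is expected to be modest, and the estimated step of a 1.3-fold higher number from compound 1 to compound 3 (0.12 log units; within the scatter) is taken to be no larger than the scatter, with a wide margin to either side. Compound 3 is therefore expected to give about 300 nM, plausibly anywhere from 80 nM to 1200 nM.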

Compound 3, half-maximal inhibitory concentration: 39 nM
Estimate against measurement, compound 3: 7.7-fold (0.89 log units) above, outside the stated range (below it).
By their numbers in this assay, from the lowest: compound 3; then compounds 2 and 1 (each within the scatter of the next).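

In this assay, for the compounds shown here, the amine nitrogen in the five-membered ring of the shared core proves to be a position where a change matters: ((pyridin-3-yl)methoxy)carbonyl in place of hydrogen gives a 5.9-fold lower number from compound 1 to compound 3 (0.77 log units; beyond the scatter), a step beyond the scatter and the first reading of any change at this site. For this pair, therefore, a hydrogen on that nitrogen is not needed for inhibition, and a much larger group is accepted on the nitrogen next to the ring atom that bears the ((1H-imidazol-2-yl)amino)methyl group. The data offer no measurement that would explain why the number falls with this group.

Going by these compounds alone, the single pair cannot show which part of the entering group accounts for the step, and an acetyl group, a benzyloxycarbonyl group with a phenyl ring in place of the pyridine, or a plain methyl on the same nitrogen would begin to separate the contribution of the carbonyl from that of the aromatic ring. As far as these compounds go, it also remains open whether the pyridine nitrogen matters at all, and whether moving it to the 2- or 4-position of the ring would preserve the step seen here.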